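A few compounds are considered here, and "the series" means these few. Any claim that something is new, unique, unknown or untested is made for them only; others in the source may bear on it.

Measured so far:
- compound 1 `CN1CCN(CC(=O)NC2CC3(N4CCCC4)CC(c4ccccc4)C2C(c2ccccc2)C3)CC1`: 50200 nM
- compound 2 `CCN(CC)CC(=O)OC1CC2(N3CCCC3)CC(c3ccccc3)C1C(c1ccccc1)C2`: 49000 nM

In an ADME assay on L6 cells (Rattus norvegicus) for cytotoxicity, read by resazurin assay, with a stated time of 72 h (on this read-out lower numbers stand for stronger inhibition and higher numbers for weaker inhibition), compound 2 gives 49000 nM, level with compound 1 within the scatter. The next structure is compound 3 `CN1CCN(CCC(=O)NC2CC3(N4CCCC4)CC(c4ccccc4)C2C(c2ccccc2)C3)CC1`, with ((2-(4-methylpiperazin-1-yl)ethyl)carbonyl)amino in place of (((diethylamino)methyl)carbonyl)oxy on a saturated ring carbon. Among the compounds with values here, the only measured step that bears on this, a 1.0-fold lower number from compound 1 to compound 2 (0.01 log units; within the scatter), involves the same leaving group and stays within the scatter. Within the data shown here, no measured compound yet carries the entering group, so the range is kept wide. No step beyond the scatter is therefore expected in this assay, in either direction. The expected change is a 1.1-fold lower number from compound 2 to compound 3 (0.04 log units; within the scatter). For compound 3 the estimated value is 45000 nM, with an expected range of 18000 nM to 100000 nM.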

Compound 3, half-maximal inhibitory concentration: 86700 nM
The estimate for compound 3 lay 1.9-fold (0.28 log units) below the measured number; the measured number falls inside the stated range.
By their numbers in this assay, from the lowest: compounds 2, 1 and 3 (each within the scatter of the next).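

On the saturated ring carbon, ((2-(4-methylpiperazin-1-yl)ethyl)carbonyl)amino in place of (((diethylamino)methyl)carbonyl)oxy gives a 1.8-fold higher number from compound 2 to compound 3 (0.25 log units; within the scatter) in this assay and leaves the number within the scatter. Within the data shown here, the chain length is varied here for the first time: (4-methylpiperazin-1-yl)methyl in place of 4-methylpiperazin-1-yl on the saturated chain carbon bound to a carbonyl carbon gives a 1.7-fold higher number from compound 1 to compound 3 (0.24 log units; within the scatter) and also stays within the scatter, so neither change moves this read-out beyond the scatter. No measurement at hand offers a reason for the size of these steps.

Among these compounds, whether a primary amine or a carboxylic acid at the end of the side chain, or a chain longer than the one in compound 3, would stay level in this assay remains open. On these data alone, the pyrrolidin-1-yl group and the phenyl groups are the same in all three compounds, so their part in the read-out is also open.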